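Chloro in Place of Nitro: Expected Cytotoxicity of Compound 3

The source may report more compounds than this note shows. Statements on the series, on what has been measured and on what is new or still open speak of the compounds shown alone.

Compound 1 `COc1ccc2c(c1)OC(c1cccc([N+](=O)[O-])c1)C(c1ccccc1)C2=O` — > 2500000 nM
Compound 2 `COc1ccc2c(c1)OC(c1ccc([N+](=O)[O-])cc1)C(c1ccccc1)C2=O` — 73200 nM

Among the compounds with values here, in a functional assay on HL-60 cells (Homo sapiens) for cytotoxicity, read by MTT assay, with a stated time of 5 days (a lower number here means that less compound is tolerated, a higher number that more compound is tolerated), compound 2 gives 73200 nM, the only number measured here. For compound 1 the result is a limit of the assay, not a number: the limit of > 2500000 nM in this assay, at which 1 of the 2 values shown sits.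

Compound 3 `COc1ccc2c(c1)OC(c1ccc(Cl)cc1)C(c1ccccc1)C2=O` differs from compound 2 by chloro in place of nitro on an aromatic carbon. Within the data shown here, the single measured step, an at least 34-fold lower number from compound 1 to compound 2 (1.53 log units; beyond the scatter), moves the nitro group to another position rather than replacing it, so it does not bear on this exchange. Among the measured compounds shown here, no measured step speaks to chloro in place of nitro, and the expected step is therefore a 1.0-fold lower number from compound 2 to compound 3 (0.02 log units; within the scatter), none beyond the scatter. Compound 3 is estimated at 70000 nM, with a range from 20000 nM to 250000 nM.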

Compound 3, half-maximal cytotoxic concentration: 2410000 nM
Estimate against measurement, compound 3: 34-fold (1.54 log units) below, and the stated range ends below it.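

In this assay, the result changes greatly with the group on this aromatic carbon: chloro in place of nitro gives a 33-fold higher number from compound 2 to compound 3 (1.52 log units; beyond the scatter). The step of an at least 1.0-fold lower number from compound 1 to compound 3 (0.01 log units; that floor lies within the scatter) shows no real separation, and compound 1 stands only at a limit of the assay: the limit of > 2500000 nM in this assay, at which 1 of the 3 values shown sits. Of the three, only compound 2 sits clearly lower, so the low number goes with nitro in the 4-nitrophenyl arrangement, not with nitro alone or with any group at that place.

From the compounds shown here alone, whether an amine or a carboxylic acid on this aromatic carbon would also give a low number stays open.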